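Carbamate trimming in the shared core series

The source may hold more compounds than are shown below. What is called first, only, known or untested is meant among the compounds shown, and "the series" means these compounds.

In a functional assay on CHO-K1 cells with Glucose-dependent insulinotropic receptor (Homo sapiens) as the target, read by a luciferase reporter, with a stated time of 5 h (a higher number here means a larger maximal response, a lower number a smaller maximal response), compound 1 `CC(C)OC(=O)N1CCC(Oc2ncnc3c2CCN3c2ccc(S(C)(=O)=O)cc2F)CC1` gives 91%, the highest of the three measured numbers. Compound 2 `CC(C)OC(=O)N1CCC(Oc2ncnc3c2CCN3c2ccc(-c3nccs3)cc2F)CC1` gives 74% and compound 3 `CC(C)OC(=O)N1CCC(Oc2ncnc3c2CCN3c2ccc(-c3cccn3C)cc2F)CC1` gives 44%; the steps of a number 17 percentage points lower from compound 1 to compound 2 (beyond the scatter), a number 47 percentage points lower from compound 1 to compound 3 (beyond the scatter) and a number 30 percentage points lower from compound 2 to compound 3 (beyond the scatter) all concern the group on the aromatic carbon. Compound 4 `CCOC(=O)N1CCC(Oc2ncnc3c2CCN3c2ccc(S(C)(=O)=O)cc2F)CC1` differs from compound 1 at another part of the core of compound 1: hydrogen in place of methyl on a saturated chain carbon bound to an oxygen next to a carbonyl group and a saturated chain carbon. Within the data shown here, no measured step touches this part, and the methylsulfonyl group of compound 1 is kept in compound 4. The change is therefore expected to give a step of a number 5 percentage points lower from compound 1 to compound 4 (within the scatter) in this assay, that is, none beyond the scatter. Compound 4 is estimated at 86%, with a range from 66% to 100%.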

Compound 4, largest response reached (reported as percent of maximum), in percent of the reference or control that the assay uses: 135%
Beside the measured number, compound 4's estimate is 49 percentage points below it, outside the stated range (above it).
By their numbers in this assay, from the lowest: compound 3; then compound 2; then compound 1; then compound 4.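

In this assay, isopropoxycarbonyl to ethoxycarbonyl with the methylsulfonyl group kept gives a number 44 percentage points higher from compound 1 to compound 4 (beyond the scatter), so the maximal response depends on this end of the molecule as well as on the aromatic group. The earlier steps shown here from compound 1 all went downward; the removal of a single methyl here gives the first step upward. Nothing available explains this step.

Open: whether ethoxycarbonyl gives a similar rise with the 1,3-thiazol-2-yl or 1-methyl-1H-pyrrol-2-yl group in place of methylsulfonyl. Also open, going by these compounds, is how methoxycarbonyl or a cyclopropyl ester would compare at this position.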